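The source may hold more compounds than are shown below. What is called first, only, known or untested is meant among the compounds shown, and "the series" means these compounds.

Measured so far:
Compound 1 `CC(C)(C)C(=O)N1Cc2c(NC(=O)C3CCNCC3)n[nH]c2C1(C)C`: 650 nM
Compound 2 `CN1CCC(C(=O)N2Cc3c(NC(=O)NCc4ccccc4)n[nH]c3C2(C)C)CC1`: 2680 nM

For the measured compounds named here, in a functional assay on A2780 cells (Homo sapiens) for antiproliferative activity, read by fluorescence, with a stated time of 72 h (on this read-out lower numbers stand for stronger inhibition and higher numbers for weaker inhibition), compound 1 gives 650 nM, the lower of the two numbers so far, and compound 2 gives 2680 nM. The gap between them lies beyond the scatter. Compound 2 differs from compound 1 in more than one place, so this gap says little about any single change.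

The next compound, compound 3 `CC(C)(C)C(=O)N1Cc2c(NC(=O)c3ccc(F)cc3)n[nH]c2C1(C)C`, keeps the core of compound 1 but carries 4-fluorophenyl in place of piperidin-4-yl on a carbonyl carbon. Going by the values given here, no measured pair isolates this replacement, so the data offer no direct precedent, and any expectation for it remains uncertain. A small step toward a higher number is expected in this assay, and there may be none beyond the scatter. The expected change is a 1.7-fold higher number from compound 1 to compound 3 (0.23 log units; within the scatter). For compound 3, the estimated value is 1100 nM, with an expected range from 300 nM to 3800 nM.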

Compound 3, half-maximal inhibitory concentration: 270 nM
For compound 3 the middle estimate is 4.1-fold (0.61 log units) above the measured one, and the stated range ends above it.
By their numbers in this assay, from the lowest: compound 3; then compound 1; then compound 2.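

In this assay, for the compounds shown here, the single change of piperidin-4-yl to 4-fluorophenyl on a carbonyl carbon gives a 2.4-fold lower number from compound 1 to compound 3 (0.38 log units; beyond the scatter) and is a modest step beyond the scatter, which the earlier gap between compound 1 and compound 2 could not show for any one change. At this position on the core of compound 1, the piperidin-4-yl group with its ring nitrogen is therefore not required for antiproliferative activity, since compound 3 keeps its activity with an aromatic ring of carbon only that carries fluorine and has no hydrogen-bond donors or acceptors. No measurement in hand explains why this replacement gives the lower number.

The compounds shown do not separate the part played by the aromatic ring from that of the fluorine, as none of them carries plain phenyl or 4-chlorophenyl at this position. They also leave open how an amine on the phenyl ring, such as 4-(dimethylamino)phenyl, or a carboxylic acid there would read out, and whether the same replacement would give a similar step on the other compounds.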